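Pentylamide of the fluorophenyl acid in the cytotoxicity series

The source may report more compounds than this note shows. Statements on the series, on what has been measured and on what is new or still open speak of the compounds shown alone.

Measured so far:
compound 1, `C=CC1=C(C(=O)O)C(c2ccc(F)cc2)OC1`, > 100000 nM
compound 2, `C=CC1=C(C(=O)NCCCCC)C(c2ccc(Cl)c(Cl)c2)OC1`, > 100000 nM
compound 3, `C=CC1=C(C(=O)Nc2ccc(OCC)cc2)C(c2ccc(OC)cc2)OC1`, > 100000 nM

Compound 1 was tested in a functional assay on QGY7701 cells (Homo sapiens) for cytotoxicity, read by MTT assay, with a stated time of 24 h (a lower number here means a stronger inhibitor, a higher number a weaker inhibitor), and its result, > 100000 nM, is a limit of the assay rather than a number. Compound 2 likewise sits at a limit in this assay, > 100000 nM. For compound 3 the result in this assay is again a limit, > 100000 nM. Thus every value in hand is a limit, which is summed up by the limit of > 100000 nM in this assay, at which 3 of the 3 values shown sit. For the measured compounds named here, there is no step between measured compounds to lean on.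

Compound 4, `C=CC1=C(C(=O)NCCCCC)C(c2ccc(F)cc2)OC1`, differs from compound 1 only at the carbonyl: pentylamino in place of hydroxy on a carbonyl carbon. Compound 2, which already carries that pentylamide on a differently substituted aryl, sits at the limit, so no movement beyond the scatter is expected in this assay; compound 4 is expected to sit at the limit too, with an estimated step that the limit leaves unreadable from compound 1 to compound 4. The estimate for compound 4 is 150000 nM, within 50000 nM to 500000 nM.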

Compound 4, half-maximal inhibitory concentration: > 100000 nM
Compound 4: no number, only a limit; the forecaster's own chance of this, stated with the estimate: 80%; the middle value is on the limit's open side.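

Compound 1 and compound 4 both give only a limit in this assay, so no step between them can be read: the limit of > 100000 nM in this assay, at which 4 of the 4 values shown sit.

The compounds shown leave open whether pentylamino in place of hydroxy on a carbonyl carbon shifts the result in this assay, and whether any compound in the series gives a readable value there.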